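Inverting both ring stereocentres of compound 3

A few compounds are considered here, and "the series" means these few. Any claim that something is new, unique, unknown or untested is made for them only; others in the source may bear on it.

Results so far in a functional assay (aorta) with Rattus norvegicus as the target (on this read-out higher numbers stand for an effect only at larger amounts of compound and lower numbers for an effect already at smaller amounts), are:

- compound 1 `CC(C)C[C@@H](N)C(=O)Nc1cc2cc[nH]c(=O)c2cc1Cl` reads 700 nM
- compound 2 `CN(C)[C@H]1CC[C@@H](C(=O)Nc2cc3cc[nH]c(=O)c3cc2Cl)CC1` reads "not determined" (no result reported)
- compound 3 `N[C@H]1CC[C@H](C(=O)Nc2cc3cc[nH]c(=O)c3cc2Cl)CC1` reads "not determined" (no result reported)

Compound 3 therefore has no number to stand on, and neither does compound 2. The next compound is compound 4 `N[C@H]1CC[C@@H](C(=O)Nc2cc3cc[nH]c(=O)c3cc2Cl)CC1`, which has the same atoms and bonds as compound 3 but differs in how each stereocentre at a saturated ring carbon is drawn (the two compounds have the same atoms and bonds and differ only in configuration as drawn: 2 of 2 stereo elements differ (all stereocentres are inverted: mirror images); a stereocentre at a saturated ring carbon is drawn r in compound 3 and s in compound 4; a stereocentre at a saturated ring carbon is drawn r in compound 3 and s in compound 4). Nothing measured here shows what such an inversion does in this assay, so no direction can be given, and no step beyond the usual scatter is expected. Among the compounds with values here, the only guide is compound 1 (700 nM), so the range stays wide. For compound 4 the expected value is 500 nM, with an estimated range from 120 nM to 2000 nM.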

Compound 4, half-maximal effective concentration: 180 nM
Estimate against measurement, compound 4: 2.8-fold (0.44 log units) above, within the range that was stated.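

In this assay, replacing 1-amino-3-methylbutyl with 4-aminocyclohexyl on the carbonyl carbon gives a 3.9-fold lower number from compound 1 to compound 4 (0.59 log units; beyond the scatter). This position therefore accepts a ring bearing the amine, and the change moves the number beyond the usual scatter. From the compounds shown here alone, compound 2 and compound 3 give no number, so steps involving them cannot be read and the role of configuration stays unknown, with only this established: the fact that compounds 3 and 4 differ only in the configuration as drawn. Still open, going by these compounds, is whether a carboxylic acid in place of the amine, or a longer chain carrying the amine, would keep this effect.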